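The compounds below may be only part of what the source reports. "The series", "measured", "known", "first", "only" and "open" are said of these compounds alone.

Measured compounds, growth inhibition in a functional assay on K562 cells (Homo sapiens) for inhibition, read by sulforhodamine B assay, with a stated time of 48 h; on this read-out lower numbers stand for stronger inhibition of growth and higher numbers for weaker inhibition of growth:
compound 1 `COc1ccc(/C=N/NC(=S)NC(C)(C)[C@H]2CC=C(C)CC2)cc1` gives 30700 nM.
compound 2 `CC1=CC[C@H](C(C)(C)NC(=S)N/N=C/c2ccc(O)cc2)CC1` gives only a limit, > 100000 nM.
compound 3 `CC1=CC[C@H](C(C)(C)NC(=S)N/N=C/c2ccccc2O)CC1` gives only a limit, > 100000 nM.

Compound 2 stands at the limit of this assay, with no number behind it. Two of the three values sit at that limit (the limit of > 100000 nM in this assay, at which 2 of the 3 values shown sit), so only compound 1 carries a real number in the set. The step of an at least 3.2-fold higher number from compound 1 to compound 2 (0.51 log units; beyond the scatter), hydrogen in place of methyl on an oxygen on an aromatic ring, is at least modest and runs toward weaker growth inhibition. The step of an at least 3.2-fold higher number from compound 1 to compound 3 (0.51 log units; beyond the scatter), 2-hydroxyphenyl in place of 4-methoxyphenyl, is of the same kind. The step that the two limits leave unreadable from compound 2 to compound 3 cannot be sized, since both ends are limits.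

Compound 4 `CC1=CC[C@H](C(C)(C)NC(=S)N/N=C/c2ccc(Cl)cc2)CC1` is not yet measured. It differs from compound 2 by chloro in place of hydroxy on an aromatic carbon. The step from compound 1 to compound 2 is the one that bears on this: taking the free hydroxy away from the position that had methoxy is the direction in which a number reappeared. A return toward the range of compound 1 is therefore expected, an at least 3.3-fold lower number from compound 2 to compound 4 (0.52 log units; beyond the scatter) in this assay. For compound 4 the expected value is 30000 nM, within 10000 nM to 100000 nM.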

Compound 4, concentration for total growth inhibition: 16900 nM
Estimate against measurement, compound 4: 1.8-fold (0.25 log units) above, within the range that was stated.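

In this assay, 4-chlorophenyl gives a measured number where 4-hydroxyphenyl gives none, with an at least 5.9-fold lower number from compound 2 to compound 4 (0.77 log units; beyond the scatter) and, against the 2-hydroxyphenyl compound, an at least 5.9-fold lower number from compound 3 to compound 4 (0.77 log units; beyond the scatter). Chloro and methoxy cannot be told apart at this position, with a 1.8-fold lower number from compound 1 to compound 4 (0.26 log units; within the scatter), so a readable number is not tied to methoxy, while the two hydroxy compounds, compound 2 and compound 3, stay at a limit. Both lower steps are floors and not sizes, each starting from a limit and not a number: the limit of > 100000 nM in this assay, at which 2 of the 4 values shown sit.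

Going by these compounds, whether an amine or a carboxylic acid in this position would go with chloro and methoxy or with hydroxy stays open. The step between compound 2 and compound 3 cannot be read, so the place of the hydroxy on the ring remains undecided.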